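A few compounds are considered here, and "the series" means these few. Any claim that something is new, unique, unknown or untested is made for them only; others in the source may bear on it.

Measured so far in a functional assay on PC-3 cells (Homo sapiens) for inhibition, read by MTT assay, with a stated time of 48 h, tested at 10 uM; on this read-out lower numbers stand for less inhibition of growth and higher numbers for more inhibition of growth at the one concentration tested:

Compound 1, `Cc1cc(=O)c2c(O)cc(OCc3ccccc3)c([C@H]3CCN(C)C[C@H]3O)c2o1`: 41%
Compound 2, `Cc1cc(=O)c2c(O)cc(OCc3ccco3)c([C@H]3CCN(C)C[C@H]3O)c2o1`: 14%
Compound 3, `CCN(CC)Cc1c(O)c([C@H]2CCN(C)C[C@H]2O)c2oc(C)cc(=O)c2c1O`: 2%

Compound 3 stands lowest of the three numbers. Its nearest neighbour is compound 2, whose value lies higher by a margin beyond the scatter, and compound 1 lies higher still. Compound 4, `Cc1cc(=O)c2c(O)c(CN3CCCCC3)c(O)c([C@H]3CCN(C)C[C@H]3O)c2o1`, has not yet been measured in this assay. It differs from compound 3 in one place: piperidin-1-yl in place of diethylamino on a saturated chain carbon bound to an aromatic carbon.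

Going by the values given here, the only measured step, a number 27 percentage points lower from compound 1 to compound 2 (beyond the scatter), concerns a change at the benzylic ether oxygen on the aromatic ring, not at the saturated chain carbon bound to an aromatic carbon where compound 4 departs from compound 3. Compounds 1 and 2 differ from compound 3 in more than one place, so they do not isolate the amine exchange either. Among the compounds with values here, with no measured step on the amine itself, a change beyond the scatter is not expected; compound 4 is estimated to sit close to compound 3, with a number 3 percentage points higher from compound 3 to compound 4 (within the scatter) as the expected step. Compound 4 is thus expected at 5%, within -5% to 20%.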

Compound 4, percent growth inhibition at one concentration: 14%
The estimate for compound 4 lay 9 percentage points below the measured number; the range from low to high includes it.
By their numbers in this assay, from the lowest: compound 3; then compounds 2 and 4 (each within the scatter of the next); then compound 1.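

In this assay the amine on the saturated chain carbon bound to an aromatic carbon proves able to move the read-out: a number 12 percentage points higher from compound 3 to compound 4 (beyond the scatter) comes with piperidin-1-yl in place of diethylamino. Compound 1 and compound 2 differ from each other elsewhere in the molecule, so they said nothing about this place, whereas this pair shows that exchanging one amine for another here gives a modest step beyond the scatter. No measurement at hand gives a reason for this step.

Going by these compounds, with only these two amines compared at this place, it remains open whether the ring itself matters or whether any other amine would do the same. A pyrrolidin-1-yl, a morpholin-4-yl or a dimethylamino group on the same carbon would help to separate these possibilities.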